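Swapping a Cyanophenyl for a Chlorophenyl on the Benzyl Ether

A few compounds are considered here, and "the series" means these few. Any claim that something is new, unique, unknown or untested is made for them only; others in the source may bear on it.

Compound 2 `COc1cc(OC)c(-c2coc3cc(OCc4ccccc4C#N)ccc3c2=O)cc1OC` is the parent of this step. In a functional assay on A-375 cells (Homo sapiens) for antiproliferative activity, read by MTT assay, with a stated time of 24 h (a lower number here means a stronger inhibitor, a higher number a weaker inhibitor), compound 2 gives 990 nM, the lowest of the two numbers measured, while compound 1 `COc1ccc2c(=O)c(-c3cc(OC)c(OC)cc3OC)coc2c1`, which carries a hydrogen in place of the 2-cyanophenyl group, gives 2640 nM. Within the data shown here, the only measured step runs a 2.7-fold lower number from compound 1 to compound 2 (0.43 log units; beyond the scatter), and it shows what attaching this group does; it says nothing about exchanging one substituted phenyl for another.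

Compound 3 `COc1cc(OC)c(-c2coc3cc(OCc4cccc(Cl)c4)ccc3c2=O)cc1OC` differs from compound 2 by 3-chlorophenyl in place of 2-cyanophenyl on a saturated chain carbon bound to an oxygen on an aromatic ring. Among the measured compounds shown here, no measured pair bears on a 2-cyanophenyl to 3-chlorophenyl exchange, so the expected change in this assay is none beyond the scatter. Compound 3 is estimated at 900 nM, within a range of 350 nM to 2500 nM, which means an expected step of a 1.1-fold lower number from compound 2 to compound 3 (0.04 log units; within the scatter).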

Compound 3, half-maximal inhibitory concentration: 980 nM
Compound 3: middle estimate off by 1.1-fold (0.04 log units), on the low side; measured number inside the range.
By their numbers in this assay, from the lowest: compounds 3 and 2 (each within the scatter of the next); then compound 1.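

In this assay, the exchange of 2-cyanophenyl for 3-chlorophenyl reads a 1.0-fold lower number from compound 2 to compound 3 (0.00 log units; within the scatter), so at this position the two groups cannot be told apart. Attaching 3-chlorophenyl in place of hydrogen reads a 2.7-fold lower number from compound 1 to compound 3 (0.43 log units; beyond the scatter), which shows that the step seen on attaching a substituted phenyl does not depend on the nitrile, as 3-chlorophenyl carries none. Nothing available here explains why the two groups read alike.

Still open, as far as these compounds go, is whether a plain phenyl with no substituent, or a group of another kind such as a carboxylic acid or an amine on the ring, would give a similar number. The two groups also differ in both substituent and ring place, so 2-chlorophenyl and 3-cyanophenyl would be needed to tell those two changes apart.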